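Swapping a Triazole for an Oxazole: Expected Liver Stability

The source may hold more compounds than are shown below. What is called first, only, known or untested is meant among the compounds shown, and "the series" means these compounds.

Measured in an ADME assay on microsomes from liver (Mus musculus) for metabolic stability; a lower number here means that the compound disappears faster, a higher number that the compound lasts longer:
Compound 1 `CC(C)C(c1nnc[nH]1)c1ccc(-c2ccc3cccc(F)c3c2)[nH]c1=O` gives 0.213 h.
Compound 2 `CC(C)C(c1ccc(-c2ccc3cccc(F)c3c2)[nH]c1=O)N1CCNC1=O` gives 0.682 h.
Compound 3 `CC(C)C(c1noc(=O)[nH]1)c1ccc(-c2ccc3cccc(F)c3c2)[nH]c1=O` reaches a limit of the assay, > 3 h, not a number.

Compound 1 holds the lowest of the two numbers shown, with compound 2 nearest. Compound 4 `CC(C)C(c1ncco1)c1ccc(-c2ccc3cccc(F)c3c2)[nH]c1=O` differs from compound 1 in one place: 1,3-oxazol-2-yl in place of 4H-1,2,4-triazol-3-yl on a saturated chain carbon bound to an aromatic carbon and a saturated chain carbon. Two measured steps start from compound 1 and both lengthen the half-life: a 3.2-fold higher number from compound 1 to compound 2 (0.51 log units; beyond the scatter), a modest step, and an at least 14-fold higher number from compound 1 to compound 3 (1.14 log units; beyond the scatter), a large step that runs into (the limit of > 3 h in this assay, at which 1 of the 3 values shown sits). Neither step installs the 1,3-oxazol-2-yl group, so they show only that this position accepts replacement without loss. A small rise is therefore expected: a 1.5-fold higher number from compound 1 to compound 4 (0.18 log units; within the scatter). Compound 4 is estimated at 0.32 h, with a range from 0.11 h to 0.95 h.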

Compound 4, half-life: 0.08 h
Compound 4: the middle estimate sits 4.0-fold (0.60 log units) above what was measured; the whole stated range lies above it.
By their numbers in this assay, from the lowest: compound 4; then compound 1; then compound 2. At a limit, above all of these: compound 3.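

This position does more than accept replacement: in this assay, the 1,3-oxazol-2-yl group gives a 2.7-fold lower number from compound 1 to compound 4 (0.43 log units; beyond the scatter), so a swap here can also shorten the half-life. The choice of group matters greatly, with an 8.5-fold lower number from compound 2 to compound 4 (0.93 log units; beyond the scatter) and an at least 37-fold lower number from compound 3 to compound 4 (1.57 log units; beyond the scatter). That last step starts from compound 3, whose entry is a limit and not a number: the limit of > 3 h in this assay, at which 1 of the 4 values shown sits.

The compounds shown do not tell whether the hydrogen-bond donor that 1,3-oxazol-2-yl lacks plays any part in the drop. They also leave open how an amine or a carboxylic acid would fare on this saturated chain carbon.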